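A few compounds are considered here, and "the series" means these few. Any claim that something is new, unique, unknown or untested is made for them only; others in the source may bear on it.

Measured in a functional assay on HCT-8 cells (Homo sapiens) for cytotoxicity; on this read-out higher numbers stand for an effect only at larger amounts of compound and lower numbers for an effect already at smaller amounts:
- compound 1 `COC1=C(C)C(=O)/C(=C(O)/C=C/c2ccccc2OC)C(=O)C1(C)C`: 4.1 ug/mL
- compound 2 `COC1=C(C)C(=O)/C(=C(O)/C=C/c2c(C)cccc2C)C(=O)C1(C)C`: 7.8 ug/mL
- compound 3 `C=Cc1ccccc1/C=C/C(O)=C1/C(=O)C(C)=C(OC)C(C)(C)C1=O`: 2.1 ug/mL

In this assay, compound 3 stands at 2.1 ug/mL, at the low end of these numbers together with compound 1. There is a 2.0-fold lower number from compound 1 to compound 3 (0.29 log units; within the scatter), and only compound 2 is clearly separated from it, with a 3.7-fold lower number from compound 2 to compound 3 (0.57 log units; beyond the scatter).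

Compound 4 `COC1=C(C)C(=O)/C(=C(O)/C=C/c2cccs2)C(=O)C1(C)C` has thiophen-2-yl in place of 2-vinylphenyl on a double-bonded chain carbon bound to a double-bonded chain carbon. All three measured steps change this same group, so all bear on the new one. Besides the two above, there is a 1.9-fold higher number from compound 1 to compound 2 (0.28 log units; within the scatter). For the measured compounds named here, none of the measured compounds carries a five-membered ring there, so the data do not test thiophen-2-yl directly.

With compound 3 at the low end of a narrow span, a small move towards a higher number is expected in this assay, no larger than the biggest measured step. The expected step is a 1.9-fold higher number from compound 3 to compound 4 (0.28 log units; within the scatter). For compound 4 the estimated value is 4 ug/mL, with an expected range of 1.8 ug/mL to 9 ug/mL.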

Compound 4, concentration for half-maximal effect: 8.6 ug/mL
For compound 4 the middle estimate is 2.2-fold (0.33 log units) below the measured one, within the range that was stated.
By their numbers in this assay, from the lowest: compounds 3, 1, 2 and 4 (each within the scatter of the next, the first and the last beyond it).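

Replacing 2-vinylphenyl with thiophen-2-yl on a double-bonded chain carbon bound to a double-bonded chain carbon gives a 4.1-fold higher number from compound 3 to compound 4 (0.61 log units; beyond the scatter) in this assay, and replacing 2-methoxyphenyl with it gives a 2.1-fold higher number from compound 1 to compound 4 (0.32 log units; beyond the scatter), so this five-membered aromatic ring does not match either of these two groups. Against 2,6-dimethylphenyl, the same change gives a 1.1-fold higher number from compound 2 to compound 4 (0.04 log units; within the scatter), which leaves thiophen-2-yl and that group indistinguishable here despite their different rings. Nothing at hand accounts for these differences.

The compounds shown leave open whether the ring size or the sulfur atom goes with the higher number, as well as how furan-2-yl or unsubstituted phenyl would stand at this position. They also leave open how a ring carrying an amine, such as 2-aminophenyl, would read out here.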